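Notes on one aryl position of the shared core

A few compounds are considered here, and "the series" means these few. Any claim that something is new, unique, unknown or untested is made for them only; others in the source may bear on it.

Compound 3 `Oc1cccc(-c2cc(-c3ccccc3)cc(-c3ccco3)n2)c1` gives 0% in an assay on isolated protein for inhibition of DNA topoisomerase 1 (Homo sapiens), with a stated time of 30 min, tested at 20 uM (a lower number here means a weaker effect, a higher number a stronger effect of the compound at the concentration tested), level with compound 1 `Oc1cccc(-c2cc(-c3ccccc3)cc(-c3ccccc3)n2)c1` at 0% and together with it the lowest of the three numbers. Its nearest neighbour is compound 1, with no change at the digits printed from compound 1 to compound 3 (within the scatter); its furthest is compound 2 `Oc1cccc(-c2cc(-c3ccccc3)cc(-c3cccs3)n2)c1` at 5.8%, with a number 5.8 percentage points lower from compound 2 to compound 3 (within the scatter). Compound 4 `Oc1cccc(-c2cc(-c3ccccc3)cc(-c3cccc(O)c3)n2)c1` is not yet measured and differs from compound 3 by 3-hydroxyphenyl in place of furan-2-yl on an aromatic carbon. Among the compounds with values here, the steps that bear on this position are a number 5.8 percentage points higher from compound 1 to compound 2 (within the scatter), no change at the digits printed from compound 1 to compound 3 (within the scatter) and a number 5.8 percentage points lower from compound 2 to compound 3 (within the scatter), each within the scatter. No step beyond the scatter is therefore expected in this assay, in either direction. Compound 4 is expected to give about 3% (0% to 15%), an estimated step of a number 3 percentage points higher from compound 3 to compound 4 (within the scatter) that should stay within the scatter.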

Compound 4, a percentage reported as inhibition, at one concentration (the size of the read-out at that concentration, not a potency): 10.5%
Compound 4: the middle estimate sits 7.5 percentage points below what was measured, and the stated range covers the measured number.
By their numbers in this assay, from the lowest: compounds 1, 3, 2 and 4 (each within the scatter of the next, the first and the last beyond it).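

In this assay this position gives its first steps beyond the scatter, a number 10.5 percentage points higher from compound 3 to compound 4 (beyond the scatter) and a number 10.5 percentage points higher from compound 1 to compound 4 (beyond the scatter), the second from hydroxy in place of hydrogen on an aromatic carbon alone. The thiophen-2-yl group stays unresolved from 3-hydroxyphenyl, with a number 4.7 percentage points higher from compound 2 to compound 4 (within the scatter), so the change does not separate compound 4 from every earlier aryl group. Nothing available accounts for these steps.

From the compounds shown here alone, whether a methoxy group in place of the hydroxy would keep the step remains open. So does the outcome with an aminophenyl or carboxyphenyl group at this position.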